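A few compounds are considered here, and "the series" means these few. Any claim that something is new, unique, unknown or untested is made for them only; others in the source may bear on it.

Of the compounds shown here, two from this series have been tested in a functional assay on HCT-116 cells (Homo sapiens) for cytotoxicity, read by resazurin assay, with a stated time of 48 h; on this read-out higher numbers stand for an effect only at larger amounts of compound and lower numbers for an effect already at smaller amounts. Compound 1 `O=C(/C=C/c1ccco1)c1ccc(NC(=O)c2ccccc2)cc1` gives 42000 nM in this assay. Compound 2 `O=C(/C=C/c1ccccc1)c1ccc(NC(=O)c2cccs2)cc1` gives 12000 nM in this assay, the lowest of the two numbers, and its nearest neighbour, compound 1, stands clearly above it, beyond the scatter. These two compounds differ in more than one place, so their values show only where each stands, not what any single change does. Compound 3 `O=C(/C=C/c1ccccc1)c1ccc(NC(=O)c2ccccc2)cc1` has not yet been measured. It differs from compound 2 in one place: phenyl in place of thiophen-2-yl on a carbonyl carbon. Among the compounds with values here, no measured pair shows this change on its own, so the expectation rests on compound 2 alone. In this assay the step is expected to be small, either none beyond the scatter or a modest rise. Compound 3 is therefore estimated at 16000 nM, within a range from 5000 nM to 48000 nM. This corresponds to an expected step of a 1.3-fold higher number from compound 2 to compound 3 (0.12 log units; within the scatter).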

Compound 3, half-maximal effective concentration: 17000 nM
Estimate against measurement, compound 3: 1.1-fold (0.03 log units) below, within the range that was stated.
By their numbers in this assay, from the lowest: compounds 2 and 3 (each within the scatter of the next); then compound 1.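

In this assay, phenyl in place of thiophen-2-yl on the carbonyl carbon gives a 1.4-fold higher number from compound 2 to compound 3 (0.15 log units; within the scatter), so this pair does not separate the five-membered aromatic ring from the six-membered one at this position. A second place now has a single-change reading as well: phenyl in place of furan-2-yl on a double-bonded chain carbon gives a 2.5-fold lower number from compound 1 to compound 3 (0.39 log units; beyond the scatter), a modest step, but one that clears the scatter. Nothing measured here offers a reason for either result.

From the compounds shown here alone, only aromatic rings appear at these two places, so it remains open how an amine, a carboxylic acid or a longer chain would fare on the carbonyl carbon. Going by these compounds, it is also open whether the change from furan-2-yl to phenyl would give a similar step with thiophen-2-yl on the carbonyl carbon.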